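This account rests on a few compounds, and the source may have more. Where it says the series, first, only, none or still open, it means among the compounds named here.

Four compounds share a scaffold in which a sulfonate ester joins two aromatic rings, one of them carrying a cyclic urea. Compound 1 `COc1cccc(OS(=O)(=O)c2ccc(N3CCN(C)C3=O)cc2)c1` has a single methoxy group on the ring bound through oxygen. In a functional assay on MCF7 cells (Homo sapiens) for antiproliferative activity, read by sulforhodamine B assay, with a stated time of 48 h (a lower number here means a stronger inhibitor, a higher number a weaker inhibitor), compound 1 gives 3000 nM. Compound 2 `COc1cc(OC)cc(OS(=O)(=O)c2ccc(N3CCN(C)C3=O)cc2)c1` differs from compound 1 by methoxy in place of hydrogen on an aromatic carbon. In this assay compound 2 gives 230 nM, a step of a 13-fold lower number from compound 1 to compound 2 (1.12 log units; beyond the scatter). Compound 3 `CCN1CCN(c2ccc(S(=O)(=O)Oc3cc(OC)cc(OC)c3)cc2)C1=O` differs from compound 2 in one place, and the step of a 15-fold higher number from compound 2 to compound 3 (1.18 log units; beyond the scatter) brings compound 3 to 3500 nM in this assay. The difference between the core of compound 1 and the core of compound 3 is not broken down here.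

Compound 4 `CCN1CCN(c2ccc(S(=O)(=O)Oc3cc(OC)c(OC)c(OC)c3)cc2)C1=O` has not yet been measured. It differs from compound 3 by methoxy in place of hydrogen on an aromatic carbon. Going by the values given here, this is the same kind of change as the one from compound 1 to compound 2, but not the same: in the earlier case the entering methoxy sat meta to a large group and meta to a methoxy group, whereas here it sits ortho to two methoxy groups and para to a large group. Among the compounds with values here, the only guide is the earlier step of a 13-fold lower number from compound 1 to compound 2 (1.12 log units; beyond the scatter), and the surroundings of the new group differ from it. Expected in this assay is therefore a smaller step of a 5.0-fold lower number from compound 3 to compound 4 (0.70 log units; beyond the scatter), with wide uncertainty. Compound 4 is estimated at 700 nM, within a range from 150 nM to 3500 nM.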

Compound 4, half-maximal inhibitory concentration: 700 nM
Compound 4: the middle estimate sits on the measured number at the digits printed; low and high end bracket the measured number.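

In this assay, putting methoxy in place of hydrogen on an aromatic carbon lowers the number once more, with a 5.0-fold lower number from compound 3 to compound 4 (0.70 log units; beyond the scatter), so the change again gives a stronger inhibitor. Set side by side, the two examples of this change point the same way, and the gap between their sizes is no larger than repeat measurements could produce: the same change on two cores in this assay, a 13-fold lower number (1.12 log units; beyond the scatter) from compound 1 to compound 2 and a 5.0-fold lower number (0.70 log units; beyond the scatter) from compound 3 to compound 4, 2.6-fold (0.42 log units) apart, within the scatter of two such steps This shows that, across these two pairs, the gain carries over from one core to another in direction and, as far as the scatter allows a reading, in size, but it does not show that the two steps are equal, and two pairs cannot establish a rule for the whole series, especially as the entering methoxy in compound 4 is ortho to two methoxy groups and para to a large group, a different setting from the earlier one.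

The compounds shown leave open how a third methoxy group would read on the core of compound 2, which carries a methyl group on the cyclic urea where compound 4 carries an ethyl group. They also leave open whether a hydroxyl group, an amine or a longer chain such as ethoxy could take the place of the entering methoxy with a similar result.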